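The source may hold more compounds than are shown below. What is called first, only, known or untested is meant among the compounds shown, and "the series" means these compounds.

- compound 1 `CCCS(=O)(=O)Nc1ccc(-c2cc(=O)c3c(O)cc(OC)c(OC(C)C)c3o2)cc1`: 2900 nM
- compound 2 `C=CC(=O)Nc1ccc(-c2cc(=O)c3c(O)cc(OC)c(OC(C)C)c3o2)cc1`: 5800 nM

In a functional assay on CWR22R cells (Homo sapiens) for antiproliferative activity, read by MTT assay, with a stated time of 3 days (a lower number here means a stronger inhibitor, a higher number a weaker inhibitor), compound 2 gives 5800 nM, and the two measured compounds cannot be told apart, with a 2.0-fold higher number from compound 1 to compound 2 (0.30 log units; within the scatter). Compound 3 `COc1cc(O)c2c(=O)cc(-c3ccc(NC(=O)N4CCCNCC4)cc3)oc2c1OC(C)C` keeps the shared core and carries 1,4-diazepan-1-yl in place of vinyl on a carbonyl carbon. Among the compounds with values here, only one measured step bears on this change. It also alters the group on a nitrogen on an aromatic ring, and it amounts to a 2.0-fold higher number from compound 1 to compound 2 (0.30 log units; within the scatter). That step offers no sign of a shift, so no step beyond the scatter is expected in this assay, in either direction. Nothing measured here carries the 1,4-diazepan-1-yl group, so the range is kept wide. The expected change is a 1.5-fold lower number from compound 2 to compound 3 (0.16 log units; within the scatter). For compound 3 the estimated value is 4000 nM, with an expected range from 1300 nM to 12000 nM.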

Compound 3, half-maximal inhibitory concentration: 6100 nM
Compound 3: middle estimate off by 1.5-fold (0.18 log units), on the low side; measured number inside the range.
By their numbers in this assay, from the lowest: compounds 1, 2 and 3 (each within the scatter of the next, the first and the last beyond it).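

In this assay, placing 1,4-diazepan-1-yl on a carbonyl carbon in place of vinyl gives a 1.1-fold higher number from compound 2 to compound 3 (0.02 log units; within the scatter), so this position takes a seven-membered non-aromatic ring with no readable change from the vinyl amide. The wider comparison with the sulfonyl compound gives a 2.1-fold higher number from compound 1 to compound 3 (0.32 log units; beyond the scatter), a modest step and the only one here beyond the scatter, although compound 2 stays within the scatter of both neighbours. Nothing available explains either step. As far as these compounds go, it remains open whether the second ring nitrogen of the 1,4-diazepan-1-yl group matters, which a piperidine or a morpholine on the same carbonyl carbon could address. Also open, from the compounds shown here alone, is how a longer alkyl chain on the sulfonyl group, or an open-chain amine on the carbonyl carbon, would read in this assay.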